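Ester Variation on a Shared Core: Toward a Furanylmethyl Ester

This account rests on a few compounds, and the source may have more. Where it says the series, first, only, none or still open, it means among the compounds named here.

Compound 1 `Nc1ncnc2c1ncn2CC(O)C(=O)OCCO` and compound 2 `CCC(C)OC(=O)C(O)Cn1cnc2c(N)ncnc21` share one core and differ only in the ester group. In a functional assay on Vero cells (Chlorocebus sabaeus) for cytotoxicity (a higher number here means that more compound is tolerated, a lower number that less compound is tolerated), compound 1 gives > 400 ug/mL, which is a limit of the assay rather than a number. In this assay compound 2 likewise gives > 400 ug/mL, again a limit and not a number. Among the compounds with values here, compound 2 thus stands at the limit of this assay, as does the only other value shown (the limit of > 400 ug/mL in this assay, at which 2 of the 2 values shown sit).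

Compound 3 `Nc1ncnc2c1ncn2CC(O)C(=O)OCc1ccco1` carries the change ((furan-2-yl)methyl in place of sec-butyl on an oxygen next to a carbonyl group). Within the data shown here, the one measured step that bears on it is a step that the two limits leave unreadable from compound 1 to compound 2, whose size is hidden by the two limits. No readable step is therefore available, and no change in this assay beyond the scatter is expected. For compound 3 the step of a number no higher from compound 2 to compound 3 (the limit leaves the size open) is expected to be essentially none. Compound 3 is estimated at 400 ug/mL, with a range from 200 ug/mL to 800 ug/mL, most probably reported again as a limit.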

Compound 3, minimum cytotoxic concentration: 40 ug/mL
The estimate for compound 3 lay 10-fold (1.00 log units) above the measured number; the measured number lies below the stated range.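

In this assay, (furan-2-yl)methyl in place of sec-butyl on an oxygen next to a carbonyl group gives an at least 10-fold lower number from compound 2 to compound 3 (1.00 log units; beyond the scatter), so the group at this position can change how much compound is tolerated, which the earlier pair could not show. Measured against the 2-hydroxyethyl ester, the change gives an at least 10-fold lower number from compound 1 to compound 3 (1.00 log units; beyond the scatter), so the drop appears from both of the earlier esters. Compound 3 is the only one of the three with a number rather than a limit: the limit of > 400 ug/mL in this assay, at which 2 of the 3 values shown sit.

The compounds shown leave open whether the lower number goes with the furan ring in particular or with any ring at this position, which a benzyl or a (tetrahydrofuran-2-yl)methyl ester would help to separate. From the compounds shown here alone, the step between compound 1 and compound 2 cannot be read, and the full size of both steps to compound 3 also remains open.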